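The source may hold more compounds than are shown below. What is called first, only, known or untested is meant among the compounds shown, and "the series" means these compounds.

Measured in a functional assay on KB cells (Homo sapiens) for antiproliferative activity, with a stated time of 72 h; on this read-out higher numbers stand for weaker inhibition and lower numbers for stronger inhibition:
compound 1 `C=C[C@@H]1C[C@@H](Cc2ccc(OC)c(O)c2)[C@H]2C(=O)C=CC(=C)[C@H]21`: 1.59 nM
compound 2 `C=C1C=CC(=O)[C@@H]2[C@H](Cc3ccc(OCOC)cc3)CC[C@H]12`: 208 nM
compound 3 `C=C1C=CC(=O)[C@@H]2[C@H](Cc3ccc(OCOC)c(F)c3)CC[C@H]12`: 76.6 nM

Compound 2, at 208 nM, has the highest number of the three and lies beyond the scatter from both others. The unmeasured compound 4 `C=C1C=CC(=O)[C@@H]2[C@H](Cc3ccc(O)cc3)CC[C@H]12` has hydrogen in place of methoxymethyl on an oxygen on an aromatic ring, so methoxymethoxy goes to hydroxy: hydrogen in place of methoxymethyl on an oxygen on an aromatic ring.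

For the measured compounds named here, no measured step makes this same change. Going by the values given here, the only single-place step is a 2.7-fold lower number from compound 2 to compound 3 (0.43 log units; beyond the scatter), a modest one with fluoro in place of hydrogen on an aromatic carbon. It gives a rough scale for a small edit in this series, but no direction for the present one. The only hint of direction is compound 1 at 1.59 nM, which also carries a hydroxy on an aromatic ring. It differs from compound 2 in other places too, so its low number cannot be credited to the hydroxy alone.

A lower number is therefore expected in this assay, with a step somewhat larger than the fluoro step but far short of the gap to compound 1. The expected change is a 4.2-fold lower number from compound 2 to compound 4 (0.62 log units; beyond the scatter). The estimate for compound 4 is 50 nM, with an expected range from 10 nM to 250 nM.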

Compound 4, half-maximal inhibitory concentration: 68.8 nM
Estimate against measurement, compound 4: 1.4-fold (0.14 log units) below, within the range that was stated.
By their numbers in this assay, from the lowest: compound 1; then compounds 4 and 3 (each within the scatter of the next); then compound 2.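

In this assay, for the compounds shown here, the methoxymethyl on this oxygen on the aromatic ring proves dispensable: with hydrogen in its place there is a 3.0-fold lower number from compound 2 to compound 4 (0.48 log units; beyond the scatter), a modest step and the first direct reading at this oxygen, as the earlier single-place step concerned an aromatic carbon. Compound 1 at 1.59 nM differs from compound 4 in more than one place, so this step alone does not account for that number, and the hydroxy cannot be credited with it. Nothing at hand gives a measured reason for the step from methoxymethoxy to hydroxy.

Still open, from the compounds shown here alone, is how far this oxygen tolerates other substituents, such as an ethyl or acetyl group, and whether an amine could stand in place of the hydroxy on the aromatic ring. Also open is what fluoro and hydroxy do when they are carried together on the same ring, since the shown compounds give each change only on its own, starting from compound 2.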